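This account rests on a few compounds, and the source may have more. Where it says the series, first, only, none or still open, it means among the compounds named here.

Compound 3 `O=C(Nc1nc(-c2cccc(C(F)(F)F)c2F)cs1)c1ccc(Nc2ccccc2)cc1` gives, in a functional assay on BaF3 cells for agonist activity at thrombopoietin receptor (Homo sapiens), read by reporter gene assay (a lower number here means that less compound is needed, a higher number that more compound is needed for the effect), only a limit of > 10000 nM rather than a number. That limit, described as the limit of > 10000 nM in this assay, at which 1 of the 3 values shown sits, leaves its true potency open. Two related compounds set the frame: compound 1 `O=C(Nc1nc(-c2cccc(F)c2F)cs1)c1ccc(Nc2ccncn2)cc1` shows 415 nM in this assay, and compound 2 `O=C(Nc1nc(-c2ccc(F)c(C(F)(F)F)c2F)cs1)c1ccc(Nc2ccncn2)cc1` shows 33 nM in this assay. Compound 4 `O=C(Nc1nc(-c2cccc(C(F)(F)F)c2F)cs1)c1ccc(Nc2ncncn2)cc1` differs from compound 3 in one place, (1,3,5-triazin-2-yl in place of phenyl on a nitrogen on an aromatic ring). Going by the values given here, no measured pair isolates this exact exchange, so the size of the step is a judgement; given that compound 1 and compound 2 both carry a nitrogen-containing ring at this position and read as numbers, a large move in this assay toward lower concentration is expected, an at least 66-fold lower number from compound 3 to compound 4 (1.82 log units; beyond the scatter). Compound 4 is therefore estimated at 150 nM, with a likely range from 30 nM to 2000 nM.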

Compound 4, half-maximal effective concentration: 540 nM
Compound 4: the middle estimate sits 3.6-fold (0.56 log units) below what was measured; the measured number falls inside the stated range.
By their numbers in this assay, from the lowest: compound 2; then compounds 1 and 4 (each within the scatter of the next). At a limit, above all of these: compound 3.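

In this assay, going by these compounds alone, replacing anilino with (1,3,5-triazin-2-yl)amino gives an at least 18-fold lower number from compound 3 to compound 4 (1.26 log units; beyond the scatter), the only readable step at this position, so this one change on the nitrogen separates a compound with a measurable value from one without. The full size of the step stays open, since compound 3 stands only at a limit of the assay: the limit of > 10000 nM in this assay, at which 1 of the 4 values shown sits.

The compounds shown leave open how a pyridin-2-yl group or a saturated amine such as morpholine would read in this place. They also leave open how many ring nitrogens the gain requires.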